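This account rests on a few compounds, and the source may have more. Where it says the series, first, only, none or still open, it means among the compounds named here.

Growth-inhibition series in a functional assay on MDA-MB-231 cells (Homo sapiens) for inhibition, read by sulforhodamine B assay, with a stated time of 72 h; a higher number here means a weaker inhibitor of growth, a lower number a stronger inhibitor of growth:
- Compound 1 `CCOC(=O)/C=C/c1ccncc1-c1ccc2c(ccn2C)c1`: 10200 nM
- Compound 2 `COC(=O)/C=C/c1ccncc1-c1ccc2ccccc2c1`: 4710 nM
- Compound 3 `Cn1ccc2cc(-c3cnccc3/C=C/C(=O)O)ccc21`: > 10000 nM

Compound 3 has no number on this read-out. Compound 3 gives > 10000 nM, which is a limit of the assay, and it stands at the limit of > 10000 nM in this assay, at which 1 of the 3 values shown sits.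

The next change leads to compound 4 `CNC(=O)/C=C/c1ccncc1-c1ccc2c(ccn2C)c1`, with methylamino in place of hydroxy on a carbonyl carbon.

Among the compounds with values here, the only measured step at this carbonyl is a step that the limit leaves unreadable from compound 1 to compound 3, so no measured step gives a size for the change. The nearest guide is compound 1, which shares its core with compound 4 and carries an ethyl ester at this carbonyl. Compound 1 stands at 10200 nM. The expectation is therefore little or no gain in this assay, with any move being towards stronger inhibition. The expected step is an at least 1.1-fold lower number from compound 3 to compound 4 (0.04 log units; that floor lies within the scatter). For compound 4 the estimated value is 9000 nM, with an expected range of 3500 nM to 20000 nM.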

Compound 4, concentration for 50% growth inhibition: 8550 nM
Compound 4: middle estimate off by 1.1-fold (0.02 log units), on the high side; low and high end bracket the measured number.
By their numbers in this assay, from the lowest: compounds 2, 4 and 1 (each within the scatter of the next, the first and the last beyond it).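

In this assay, the change from carboxy to methylcarbamoyl on this carbonyl carbon reads as an at least 1.1-fold lower number from compound 3 to compound 4 (0.06 log units; that floor lies within the scatter), which is a floor and not a measured size. The value of compound 3 is a limit of the assay and not a number: the limit of > 10000 nM in this assay, at which 1 of the 4 values shown sits.

Methylamino in place of ethoxy on the same carbonyl carbon gives a 1.2-fold lower number from compound 1 to compound 4 (0.08 log units; within the scatter), so on this core the methylcarbamoyl and ethyl ester forms cannot be told apart in this assay.

As far as these compounds go, it remains open whether a dimethylamino or propylamino group on this carbonyl carbon would move the number beyond the scatter on the shared core. Compound 2 differs from compound 1 in more than one place, so the part played by its methyl ester cannot be separated from that of its core.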